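A few compounds are considered here, and "the series" means these few. Any claim that something is new, unique, unknown or untested is made for them only; others in the source may bear on it.

Of the compounds shown here, three that share one core have been measured in a functional assay on KB cells (Homo sapiens) for cytotoxicity, read by MTT assay, with a stated time of 72 h; a lower number here means a stronger inhibitor, a higher number a weaker inhibitor. Compound 1 `[O-][n+]1nc(NCOC2CCCCC2)[n+]([O-])c2ccccc21` gives 22100 nM in this assay. Compound 2 `O=[N+]([O-])c1cccc(COCNc2n[n+]([O-])c3ccccc3[n+]2[O-])c1` gives 16600 nM. Compound 3 `COc1ccc2c(c1)[n+]([O-])nc(NCOCc1ccccc1)[n+]2[O-]` gives 18100 nM, a number that lies between the other two and differs from each of them by less than the usual scatter, so the three cannot be told apart on these numbers.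

Compound 4 `[O-][n+]1nc(NCOCc2ccccc2)[n+]([O-])c2ccccc21` has not yet been measured in this assay. It differs from compound 3 in a single place: hydrogen in place of methoxy on an aromatic carbon. Compound 1 likewise carries no methoxy on its core and gives 22100 nM, a value indistinguishable from that of compound 3. Among the compounds with values here, nothing among the measured compounds suggests that hydrogen in place of methoxy moves the number by more than the scatter, so the expected step is a 1.1-fold higher number from compound 3 to compound 4 (0.04 log units; within the scatter), meaning no change beyond the scatter in either direction. Compound 4 is therefore estimated at 20000 nM in this assay, with a range from 10000 nM to 40000 nM.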

Compound 4, half-maximal inhibitory concentration: 12300 nM
Estimate against measurement, compound 4: 1.6-fold (0.21 log units) above; the measured number falls inside the stated range.
By their numbers in this assay, from the lowest: compounds 4, 2, 3 and 1 (each within the scatter of the next).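

Within the data shown here, compound 4 gives the first direct reading of this position: in this assay, hydrogen in place of methoxy on an aromatic carbon of the shared core gives a 1.5-fold lower number from compound 3 to compound 4 (0.17 log units; within the scatter), which lies within the scatter, so the two groups cannot be told apart here. The two other single changes also stay within the scatter: hydrogen in place of nitro on an aromatic carbon gives a 1.3-fold lower number from compound 2 to compound 4 (0.13 log units; within the scatter), and benzyl in place of cyclohexyl on the oxygen gives a 1.8-fold lower number from compound 1 to compound 4 (0.25 log units; within the scatter). No measurement at hand offers a cause for these small steps.

Going by these compounds, it remains open whether an amine or a carboxylic acid on this aromatic carbon would move the number beyond the scatter. The same question stands for a longer chain in place of benzyl on the oxygen.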